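From cyclopentyl to a phenyl group on the amine

The compounds below may be only part of what the source reports. "The series", "measured", "known", "first", "only" and "open" are said of these compounds alone.

Compound 1 `CCCc1ccc(NC2=CC(=O)c3nc4n(c3C2=O)[C@H]2OC[C@@H](O)[C@H]2OC4)cc1` gives 4660 nM
Compound 2 `O=C1C(NC2CCCC2)=CC(=O)c2c1nc1n2[C@H]2OC[C@@H](O)[C@H]2OC1` gives > 16000 nM
Compound 3 `O=C1C=C(Nc2cccc(F)c2)C(=O)c2c1nc1n2[C@H]2OC[C@@H](O)[C@H]2OC1` gives 5500 nM

In a functional assay on MCF7 cells (Homo sapiens) for inhibition, read by sulforhodamine B assay (a higher number here means a weaker inhibitor, a lower number a stronger inhibitor), compound 2 gives > 16000 nM as its reading, which is a limit of the assay and not a number. Compound 4 `O=C1C(Nc2ccc(C(F)(F)F)cc2)=CC(=O)c2c1nc1n2[C@H]2OC[C@@H](O)[C@H]2OC1` changes one group on the amine nitrogen: 4-(trifluoromethyl)phenyl in place of cyclopentyl on an amine nitrogen is the whole difference. Among the measured compounds shown here, the one measured step that bears on this is a 1.2-fold higher number from compound 1 to compound 3 (0.07 log units; within the scatter) and it swaps one phenyl group for another. Compound 1 and compound 3 both carry a phenyl group and both gave numbers, but their amine sits elsewhere on the core than in compound 4, so this guide is loose. The expected change is an at least 2.6-fold lower number from compound 2 to compound 4 (0.42 log units; beyond the scatter) towards a stronger inhibitor. For compound 4 the estimate is 6000 nM with an expected range from 2000 nM to 16000 nM in this measurement.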

Compound 4, half-maximal inhibitory concentration: > 4000 nM
Compound 4 ended at the assay's limit (the forecaster's own chance of this, stated with the estimate: 15%); the middle value is on the limit's open side.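

Compound 2 and compound 4 both gave only limits of the assay, not numbers, and the step between them cannot be read. As far as these compounds go, whether 4-(trifluoromethyl)phenyl in place of cyclopentyl changes inhibition in this assay stays open.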